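Swapping a methylfuran for a methylphenyl ring

This account rests on a few compounds, and the source may have more. Where it says the series, first, only, none or still open, it means among the compounds named here.

Measured so far:
Compound 1, `Clc1ccc(-c2cc(-c3ccc(Cl)o3)cc(-c3cccs3)n2)cc1`, in a functional assay on HeLa cells (Homo sapiens) for cytotoxicity, in the presence of a further agent that is not named here; a higher number here means a weaker inhibitor, a lower number a stronger inhibitor: 21300 nM
Compound 3, `Cc1ccc(-c2cc(-c3ccc(Cl)o3)cc(-c3cccs3)n2)cc1`, in this assay: 16300 nM
Compound 2, `Cc1ccc(-c2cc(-c3ccc(Cl)o3)cc(-c3ccsc3)n2)o1`, in this assay: > 50000 nM, which is a limit of the assay and not a number.

Compound 2 stands at the weak end of what has been seen, as its result is the limit of the limit of > 50000 nM in this assay, at which 1 of the 3 values shown sits. The step to compound 4, `Cc1ccccc1-c1cc(-c2ccc(Cl)o2)cc(-c2ccsc2)n1`, changes one ring: 2-methylphenyl in place of 5-methylfuran-2-yl on an aromatic carbon. Going by the values given here, the only step measured so far is a 1.3-fold lower number from compound 1 to compound 3 (0.12 log units; within the scatter), a swap of methyl for chloro on a phenyl ring that leaves the number within the scatter; it says nothing about a furan ring against a phenyl ring. Compounds 1 and 3 differ from compound 2 in more than one place, so their values, both well within measurable range, give no clean comparison either. The expected step of an at least 1.2-fold lower number from compound 2 to compound 4 (0.09 log units; that floor lies within the scatter) is therefore uncertain, with a modest chance of a real gain. Compound 4 is estimated at 40000 nM, within 12000 nM to 130000 nM.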

Compound 4, half-maximal inhibitory concentration: 9770 nM
Compound 4: middle estimate off by 4.1-fold (0.61 log units), on the high side; measured number below the stated range.
By their numbers in this assay, from the lowest: compounds 4, 3 and 1 (each within the scatter of the next, the first and the last beyond it). At a limit, above all of these: compound 2.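

Putting 2-methylphenyl in place of 5-methylfuran-2-yl on the carbon next to the ring nitrogen gives an at least 5.1-fold lower number from compound 2 to compound 4 (0.70 log units; beyond the scatter) in this assay. Going by these compounds alone, the earlier step, a 1.3-fold lower number from compound 1 to compound 3 (0.12 log units; within the scatter), stayed within the scatter and concerned a phenyl ring elsewhere on the core, so this is the first sign that the group at this position can move the number by more than the scatter. Going by these compounds, the true size of the step remains unknown, since compound 2 gives a limit of the assay and not a number: the limit of > 50000 nM in this assay, at which 1 of the 4 values shown sits.

On these data alone, whether the gain belongs to the six-membered ring or to its methyl stays open, and a plain phenyl at this position would separate the two. Also open, as far as these compounds go, is how an amine or a carboxylic acid on this ring would read in this assay.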